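Shortening the ester chain and replacing it with an azide

The compounds below may be only part of what the source reports. "The series", "measured", "known", "first", "only" and "open" are said of these compounds alone.

Compound 1 `C#CCCCCOC(=O)/C=C/c1ccc(OC(C)=O)c(OC(C)=O)c1` belongs to a set of cinnamate-type compounds tested in an assay for inhibition of Polyunsaturated fatty acid 5-lipoxygenase (Homo sapiens), read by HPLC, with a stated time of 10 min; a higher number here means a weaker inhibitor, a lower number a stronger inhibitor. In this assay compound 1 gives 920 nM, the highest of the two numbers obtained; its nearest neighbour is compound 2 `C#CCCCCCCCCOC(=O)/C=C/c1ccc(OC(C)=O)c(OC(C)=O)c1`, which gives 180 nM. Within the data shown here, the only single-point step measured so far is a 5.1-fold lower number from compound 1 to compound 2 (0.71 log units; beyond the scatter). Compound 3 `C#CCCOC(=O)/C=C/c1ccc(F)c(F)c1` sits at the limit of the assay (the limit of > 10000 nM in this assay, at which 1 of the 3 values shown sits), and compound 3 gives only > 10000 nM, not a number.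

Compound 4 `CC(=O)Oc1ccc(/C=C/C(=O)CCCN=[N+]=[N-])cc1OC(C)=O` differs from compound 1 by 3-azidopropyl in place of (hex-5-yn-1-yl)oxy on a carbonyl carbon. Of the measured steps, only the chain lengthening from compound 1 to compound 2 bears on it, and that step pointed to a lower number with a longer chain. Compound 4 carries a shorter chain than compound 1, so the expected change is in the opposite direction, a modest rise in the number. Compound 4 is therefore expected to give about 2500 nM, with a range from 800 nM to 8000 nM, which as a step means an estimated 2.7-fold higher number from compound 1 to compound 4 (0.43 log units; beyond the scatter).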

Compound 4, half-maximal inhibitory concentration: 1300 nM
The estimate for compound 4 lay 1.9-fold (0.28 log units) above the measured number, within the range that was stated.
By their numbers in this assay, from the lowest: compound 2; then compounds 1 and 4 (each within the scatter of the next). At a limit, above all of these: compound 3.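

In this assay, putting 3-azidopropyl in place of (hex-5-yn-1-yl)oxy on this carbonyl carbon gives a 1.4-fold higher number from compound 1 to compound 4 (0.15 log units; within the scatter), so compounds 1 and 4 cannot be told apart. The earlier step changed only the length of an alkyne chain, whereas this one shows that the chain oxygen and the triple bond can both leave together without a change beyond the scatter, at least in this pair. Nothing measured for these compounds explains why the two groups give such similar numbers.

As far as these compounds go, this single swap changes the chain oxygen, the chain end and the chain length at once, so the share of each stays unknown. From the compounds shown here alone, it also stays open whether a longer chain ending in azide, or a chain ending in an amine, would give a lower number, as the longer alkyne chain of compound 2 did.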